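The source may report more compounds than this note shows. Statements on the series, on what has been measured and on what is new or still open speak of the compounds shown alone.

Compound 1 `O=C(NO)c1ccc(-c2nc(N3CCCCC3)c3ccccc3n2)cc1` gives 66.4% in an assay on isolated protein for inhibition of protein deacetylase HDAC6 (Homo sapiens), tested at 0.5 uM; on this read-out lower numbers stand for less inhibition and higher numbers for more inhibition at the one concentration tested (going by the name of the read-out).
Compound 2 `O=C(NO)c1ccc(-c2nc(N3CCC(F)(F)CC3)c3ccccc3n2)cc1` gives 71.7% in this assay.
Compound 3 `COc1cc(OC)c2c(N3CCCCC3)nc(-c3ccc(C(=O)NO)cc3)nc2c1` gives 62.5% in this assay.

Compound 3 has the smallest of the three numbers, yet both compound 1 and compound 2 lie within the usual scatter of it, so no real order among the three is shown. Compound 4 `COc1cc(OC)c2c(N3CCC(F)(F)CC3)nc(-c3ccc(C(=O)NO)cc3)nc2c1` differs from compound 3 in one place: 4,4-difluoropiperidin-1-yl in place of piperidin-1-yl on an aromatic carbon. The same swap has been measured once, on the core of compound 1, where it gave a number 5.3 percentage points higher from compound 1 to compound 2 (within the scatter). Only a step of that size, or none beyond the scatter, is therefore expected in this assay for compound 4. Compound 4 is estimated at 67%, between 55% and 79%, an expected step of a number 4.5 percentage points higher from compound 3 to compound 4 (within the scatter).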

Compound 4, a percentage reported as inhibition, at one concentration (the size of the read-out at that concentration, not a potency): 53.2%
For compound 4 the middle estimate is 13.8 percentage points above the measured one; measured number outside the range, below it.
By their numbers in this assay, from the lowest: compounds 4, 3, 1 and 2 (each within the scatter of the next, the first and the last beyond it).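

The swap of piperidin-1-yl for 4,4-difluoropiperidin-1-yl at this position now has a second reading, on the core of compound 3: a number 9.3 percentage points lower from compound 3 to compound 4 (within the scatter). Neither step alone lies beyond the scatter, but together they show that the swap does not carry a fixed step from one core to the other. What it does here depends on the core it sits on: the same change on two cores in this assay, a number 5.3 percentage points higher (within the scatter) from compound 1 to compound 2 and a number 9.3 percentage points lower (within the scatter) from compound 3 to compound 4, 14.6 percentage points apart, beyond the scatter of two such steps

The compounds shown leave open how other amines at this position, such as morpholin-4-yl or dimethylamino, would behave on these two cores. They also leave open whether such groups would differ between the cores as this swap does.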